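Chlorine Position on the Urea Aryl in 5-Lipoxygenase Inhibitors

The source may report more compounds than this note shows. Statements on the series, on what has been measured and on what is new or still open speak of the compounds shown alone.

Compound 1 `Cc1cc(OCc2nc3ccccc3s2)ccc1NC(=O)Nc1cccc(Cl)c1` was tested in an assay on isolated protein for inhibition of Polyunsaturated fatty acid 5-lipoxygenase (Homo sapiens), read by HPLC, with a stated time of 10 min (on this read-out lower numbers stand for stronger inhibition and higher numbers for weaker inhibition), where compound 1 gives 160 nM. Compound 2 `Cc1cc(OCc2nc3ccccc3s2)ccc1NC(=O)Nc1ccc(Cl)cc1` differs from it by 4-chlorophenyl in place of 3-chlorophenyl on an amide-type nitrogen; in this assay compound 2 gives 570 nM, which is a step of a 3.6-fold higher number from compound 1 to compound 2 (0.55 log units; beyond the scatter). Compound 3 `O=C(Nc1ccc(OCc2nc3ccccc3s2)cc1)Nc1cccc(Cl)c1` differs from compound 1 by hydrogen in place of methyl on an aromatic carbon, and in this assay compound 3 gives 170 nM, a step of a 1.1-fold higher number from compound 1 to compound 3 (0.03 log units; within the scatter), so compound 1 and compound 3 cannot be told apart on this read-out.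

Compound 4 `O=C(Nc1ccc(Cl)cc1)Nc1ccc(OCc2nc3ccccc3s2)cc1` has not yet been measured. For the measured compounds named here, it differs from compound 3 by 4-chlorophenyl in place of 3-chlorophenyl on an amide-type nitrogen, the same change, made at the same place, as the one from compound 1 to compound 2. Going by the values given here, its expected value therefore rests on the step of a 3.6-fold higher number from compound 1 to compound 2 (0.55 log units; beyond the scatter) applied to the value of compound 3 170 nM, with the caution that only one earlier instance of this change exists.

Compound 4 is expected to give 600 nM in this assay, estimated to lie between 250 nM and 1500 nM. This estimate means an expected step of a 3.5-fold higher number from compound 3 to compound 4 (0.55 log units; beyond the scatter).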

Compound 4, half-maximal inhibitory concentration: 1010 nM
The estimate for compound 4 lay 1.7-fold (0.23 log units) below the measured number; the measured number falls inside the stated range.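

In this assay, 4-chlorophenyl in place of 3-chlorophenyl on an amide-type nitrogen gives a 5.9-fold higher number from compound 3 to compound 4 (0.77 log units; beyond the scatter), so the change carries over from the core of compound 1 to the core of compound 3 in direction and, within the scatter, in size: the same change on two cores in this assay, a 3.6-fold higher number (0.55 log units; beyond the scatter) from compound 1 to compound 2 and a 5.9-fold higher number (0.77 log units; beyond the scatter) from compound 3 to compound 4, 1.7-fold (0.22 log units) apart, within the scatter of two such steps

Hydrogen in place of methyl on an aromatic carbon, read with the 4-chlorophenyl group in place, gives a 1.8-fold higher number from compound 2 to compound 4 (0.25 log units; within the scatter), which matches the earlier small step within the scatter: the same change on two cores in this assay, a 1.1-fold higher number (0.03 log units; within the scatter) from compound 1 to compound 3 and a 1.8-fold higher number (0.25 log units; within the scatter) from compound 2 to compound 4, 1.7-fold (0.22 log units) apart, within the scatter of two such steps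

These four compounds form a single closed set of pairs in one assay, so they show that the change transferred between these two cores but do not show that it would transfer to any other core in the series.

The compounds shown leave open what a fluorine or a methoxy group in place of the chlorine would give on either core. They also leave open whether a carboxylic acid or an amine on that aryl ring would keep the numbers seen for the 3-chlorophenyl compounds.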